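This account rests on a few compounds, and the source may have more. Where it says the series, first, only, none or still open, it means among the compounds named here.

In an ADME assay on HepG2 cells (Homo sapiens) for cytotoxicity, read by MTT assay, with a stated time of 24 h (on this read-out higher numbers stand for lower toxicity in this test and lower numbers for higher toxicity in this test), compound 1 `O=C(OCCCc1cn(-c2ccnc3cc(Cl)ccc23)nn1)c1ccccc1` gives 1200000 nM and compound 2 `COc1ccc(C(=O)OCCCc2cn(-c3ccnc4cc(Cl)ccc34)nn2)cc1` gives 347000 nM. Compound 3 `O=C(OCCCc1cn(-c2ccnc3cc(Cl)ccc23)nn1)c1ccc(C(F)(F)F)cc1` gives > 2170000 nM, which is a limit rather than a number. The step of an at least 1.8-fold higher number from compound 1 to compound 3 (0.25 log units; that floor lies within the scatter) sits at a floor that stays within the scatter, while the step of an at least 6.2-fold higher number from compound 2 to compound 3 (0.79 log units; beyond the scatter) is at least modest. Compound 4 `CC(C)(C)c1ccc(C(=O)OCCCc2cn(-c3ccnc4cc(Cl)ccc34)nn2)cc1` differs from compound 3 by tert-butyl in place of trifluoromethyl on an aromatic carbon. Going by the values given here, no measured step swaps one such group for another, so the two steps leading to compound 3 are the only guide, and no shift beyond the scatter is expected in this assay, with a fair chance that only a limit is reported again. Compound 4 is therefore estimated at 2000000 nM, between 600000 nM and 5000000 nM. This amounts to an expected step of an at least 1.0-fold lower number from compound 3 to compound 4 (0.03 log units; that floor lies within the scatter).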

Compound 4, half-maximal cytotoxic concentration: > 2230000 nM
Compound 4: a limit, no number; the forecaster's own chance of this, stated with the estimate: 55%; middle value at least 1.1-fold (0.04 log units) from the limit.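

Like trifluoromethyl, tert-butyl in this place leaves this assay at a limit rather than a number, whereas methoxy gave a number. Against methoxy the change is an at least 6.4-fold higher number from compound 2 to compound 4 (0.80 log units; beyond the scatter), while against hydrogen it is an at least 1.8-fold higher number from compound 1 to compound 4 (0.26 log units; that floor lies within the scatter). Compound 3 and compound 4 both stand as limits, so the step between them cannot be read.

On these data alone, whether tert-butyl and trifluoromethyl differ at all in this test remains open. As far as these compounds go, it is also open whether an amine or a carboxylic acid in this place would behave like methoxy or also end at a limit.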